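Shortening the side chain of compound 2

The compounds below may be only part of what the source reports. "The series", "measured", "known", "first", "only" and "open" are said of these compounds alone.

Measured in a functional assay on the whole organism with Mus musculus as the target, in the rotarod test; a higher number here means that more compound is needed for the effect, a lower number that less compound is needed:
- compound 1 `CC(=O)NCC(=O)N(C)c1ccc(Cl)cc1C(=O)c1ccccc1Cl`: 58 mg/kg
- compound 2 `CCCCCCC(=O)NCC(=O)N(C)c1ccc(Cl)cc1C(=O)c1ccccc1Cl`: 70 mg/kg

Going by the values given here, compound 2 has only one measured neighbour, and the two numbers lie within the scatter of each other. Compound 3 `CCCC(=O)NCC(=O)N(C)c1ccc(Cl)cc1C(=O)c1ccccc1Cl` shortens its chain: hydrogen in place of propyl on a saturated chain carbon, three bonds along the chain from a carbonyl carbon. Among the compounds with values here, the one measured step that bears on this, pentyl in place of hydrogen on a saturated chain carbon bound to a carbonyl carbon, is a 1.2-fold higher number from compound 1 to compound 2 (0.08 log units; within the scatter). Removing propyl goes part of the way back along that step, so no change beyond the scatter is expected in this assay. The estimated step is a 1.1-fold lower number from compound 2 to compound 3 (0.05 log units; within the scatter). For compound 3 the expected value is 63 mg/kg, with an estimated range of 35 mg/kg to 110 mg/kg.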

Compound 3, dose for half-maximal effect: 55.2 mg/kg
Compound 3: the middle estimate sits 1.1-fold (0.06 log units) above what was measured; measured number inside the range.
By their numbers in this assay, from the lowest: compounds 3, 1 and 2 (each within the scatter of the next).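

In this assay, removing propyl from the chain of compound 2 gives a small step (a 1.3-fold lower number from compound 2 to compound 3 (0.10 log units; within the scatter)), and the step from the short chain of compound 1 is just as small (a 1.1-fold lower number from compound 1 to compound 3 (0.02 log units; within the scatter)). The intermediate chain of compound 3 therefore fits with the shorter and longer chains: across these compounds, changing chain length at this position produces no step beyond the scatter. No measured evidence here explains this flat result.

Still open, on these data alone, is whether the number would move with an amine or a carboxylic acid at the end of the chain, or with a much longer chain.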